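Ethyl in Place of Methyl on the Amide Side Chain

The compounds below may be only part of what the source reports. "The series", "measured", "known", "first", "only" and "open" are said of these compounds alone.

Among the compounds with values here, compound 3 `CC(C(=O)N1CCN(c2ccc(F)cc2)CC1)N1C(=O)CCC1=O` gives 50% in a functional assay on the whole organism (strain Swiss) with Mus musculus as the target, in the maximal electroshock model, with a stated time of 0.5 h, at a dose of 300 mg/kg by the intraperitoneal route (on this read-out lower numbers stand for a weaker effect and higher numbers for a stronger effect at the one dose given), the second highest of the three numbers known, with compound 1 `CCC(C(=O)N1CCN(c2ccccc2F)CC1)N1C(=O)CCC1=O` at 100% and compound 2 `CCC(C(=O)N1CCN(c2ccc(Cl)cc2)CC1)N1C(=O)CCC1=O` at 0%. Compound 4 `CCC(C(=O)N1CCN(c2ccc(F)cc2)CC1)N1C(=O)CCC1=O` differs from compound 3 by methyl in place of hydrogen on a saturated chain carbon, two bonds along the chain from an amide-type nitrogen in a ring and a carbonyl carbon. Within the data shown here, the one measured step, a number 100 percentage points lower from compound 1 to compound 2 (beyond the scatter), concerns the ring on the amine nitrogen and not this chain carbon, so it offers no direct guide. Compound 1, which carries the same ethyl chain as compound 4 but a different ring, shows the highest number, and compound 2 the lowest. Among the measured compounds shown here, with no step covering this change, a modest rise is expected, a number 15 percentage points higher from compound 3 to compound 4 (beyond the scatter), so compound 4 is estimated at 65%, between 25% and 100%.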

Compound 4, a percentage reported as activity, at one dose (the size of the read-out at that dose, not a potency): 25%
Compound 4: the middle estimate sits 40 percentage points above what was measured; measured number inside the range.
By their numbers in this assay, from the lowest: compound 2; then compound 4; then compound 3; then compound 1.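

With the 4-fluorophenyl group kept, methyl to ethyl on this chain carbon gives a number 25 percentage points lower from compound 3 to compound 4 (beyond the scatter) in this assay and so costs effect at the one dose given. With the ethyl chain kept, fluoro in place of chloro gives a number 25 percentage points higher from compound 2 to compound 4 (beyond the scatter) while 4-fluorophenyl in place of 2-fluorophenyl gives a number 75 percentage points lower from compound 1 to compound 4 (beyond the scatter) and this is the largest of the three new steps. Nothing measured here explains these steps.

On these data alone, whether a longer chain such as propyl, or an amine on this chain carbon, would lower the number further stays open, as does the effect of the same methyl with the 2-fluorophenyl group.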